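The source may hold more compounds than are shown below. What is called first, only, known or untested is meant among the compounds shown, and "the series" means these compounds.

Compound 1 `C[C@H]1CC[C@@H]2[C@@H](OC(=O)[C@]23CC(c2c(Cl)cccc2Cl)=NO3)[C@]2(C)C(=O)C=C[C@@]12O` carries a 2,6-dichlorophenyl on a carbon with a double bond to nitrogen, and in a functional assay on PC-3 cells (Homo sapiens) for cytotoxicity, read by sulforhodamine B assay, with a stated time of 48 h (on this read-out higher numbers stand for weaker inhibition and lower numbers for stronger inhibition), compound 1 gives 56000 nM. Compound 2 `C[C@H]1CC[C@@H]2[C@@H](OC(=O)[C@]23CC(c2ccc(O)cc2)=NO3)[C@]2(C)C(=O)C=C[C@@]12O` keeps the same core with a 4-hydroxyphenyl at that carbon with a double bond to nitrogen; in this assay compound 2 gives 20000 nM. Among the compounds with values here, the one single-site step measured so far runs a 2.8-fold lower number from compound 1 to compound 2 (0.45 log units; beyond the scatter). On the two numbers in hand compound 2 stands lowest, its nearest neighbour being compound 1 at 56000 nM.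

Compound 3 `C[C@H]1CC[C@@H]2[C@@H](OC(=O)[C@]23CC(c2cccc([N+](=O)[O-])c2)=NO3)[C@]2(C)C(=O)C=C[C@@]12O` keeps the core of compound 2 and exchanges the aromatic group: 3-nitrophenyl in place of 4-hydroxyphenyl on a carbon with a double bond to nitrogen. Within the data shown here, only one measured step bears on this site, a 2.8-fold lower number from compound 1 to compound 2 (0.45 log units; beyond the scatter), and it shows that swapping the aryl ring moves the number modestly; no step compares a nitrophenyl with a hydroxyphenyl directly. A small step, close to the scatter and if anything toward a higher number, is therefore expected: a 1.5-fold higher number from compound 2 to compound 3 (0.18 log units; within the scatter). Compound 3 is estimated at 30000 nM in this assay, with a range of 10000 nM to 90000 nM.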

Compound 3, half-maximal inhibitory concentration: 55000 nM
Compound 3: middle estimate off by 1.8-fold (0.26 log units), on the low side; measured number inside the range.
By their numbers in this assay, from the lowest: compound 2; then compounds 3 and 1 (each within the scatter of the next).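

In this assay, moving from 4-hydroxyphenyl to 3-nitrophenyl on the carbon with a double bond to nitrogen gives a 2.8-fold higher number from compound 2 to compound 3 (0.44 log units; beyond the scatter), so the earlier gain does not extend to a second change of aryl group. The other new step, a 1.0-fold lower number from compound 1 to compound 3 (0.01 log units; within the scatter), leaves 3-nitrophenyl and 2,6-dichlorophenyl indistinguishable at this position, and among these three compounds only compound 2 stands apart from the others, with the 4-hydroxyphenyl group being the only aryl group here that carries a hydroxyl. No evidence is at hand to explain this separation.

The three compounds do not show whether the separation depends on the hydroxyl itself, on where it sits on the ring, or on the absence of nitro and chloro groups, since each aryl group differs from the others in both substituent and placement. An amine or a methyl ether in place of the hydroxyl would bear on this, and a carboxylic acid or a longer chain would show whether this position can give a number well under that of compound 2, 20000 nM.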